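The source may report more compounds than this note shows. Statements on the series, on what has been measured and on what is new or still open speak of the compounds shown alone.

Measured compounds:
Compound 1 `CNC(=O)c1cc(Oc2ccc(NC(=O)c3nn(-c4ccccc4C(F)(F)F)c(=O)cc3C)cc2F)ccn1`. In a functional assay on HepG2 cells (Homo sapiens) for cytotoxicity, read by MTT assay, with a stated time of 72 h (a lower number here means a stronger inhibitor, a higher number a weaker inhibitor), compound 1 gives > 40000 nM, which is a limit of the assay rather than a number.
Compound 2 `Cc1cc(=O)n(-c2ccccc2C(F)(F)F)nc1C(=O)Nc1ccc(Oc2ncnc3sccc23)cc1`. In this assay compound 2 gives > 40000 nM, again a limit rather than a number.

Both measured values sit at the same place: the limit of > 40000 nM in this assay, at which 2 of the 2 values shown sit. So compound 2 stands at the edge of what the assay can report, with no measurable effect on the cells in the tested range, and compound 1 stands there too. Compound 3 `Cc1cc(=O)n(-c2ccccc2C(F)(F)F)nc1C(=O)Nc1ccc(Oc2ncnc3sccc23)c(F)c1` is not yet measured. It differs from compound 2 by fluoro in place of hydrogen on an aromatic carbon, a fluoro in place of hydrogen on an aromatic carbon. Among the measured compounds shown here, no step between measured compounds is available, so nothing here shows how such a change has shifted this assay. Compound 2 sits at the limit > 40000 nM. The step from compound 2 to compound 3 is estimated as a number no higher from compound 2 to compound 3 (the limit leaves the size open), no change beyond the scatter. Compound 3 is therefore expected to give 40000 nM, between 20000 nM and 100000 nM, most likely reported only as a limit again.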

Compound 3, half-maximal inhibitory concentration: 14700 nM
For compound 3 the middle estimate is 2.7-fold (0.43 log units) above the measured one; the whole stated range lies above it.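

In this assay, fluoro in place of hydrogen on an aromatic carbon, ortho to a large group and meta to a large group, gives an at least 2.7-fold lower number from compound 2 to compound 3 (0.43 log units; beyond the scatter), so this position can influence the effect on the cells. Replacing the group on an oxygen on an aromatic ring, with a five-membered and a six-membered aromatic ring in place of a single six-membered one, gives an at least 2.7-fold lower number from compound 1 to compound 3 (0.43 log units; beyond the scatter). Each step has only a minimum size, since its starting value is a limit of the assay: the limit of > 40000 nM in this assay, at which 2 of the 3 values shown sit.

The compounds shown leave open whether a chlorine, a methyl group or an amine at this position would lower the number as fluoro does. They also leave open how large the step from hydrogen to fluoro really is.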